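Shortening a side chain at the cytotoxicity limit

This account rests on a few compounds, and the source may have more. Where it says the series, first, only, none or still open, it means among the compounds named here.

In an ADME assay on L929 cells (Mus musculus) for cytotoxicity, with a stated time of 72 h (on this read-out higher numbers stand for weaker inhibition and lower numbers for stronger inhibition), compound 1 (`CCOC(=O)COc1ccc2c(c1)B(O)OC2`) gives > 10 ug/mL, which is a limit of the assay and not a number. Compound 2 (`CCCC(=O)C(CC)Oc1ccc2c(c1)B(O)OC2`) gives > 10 ug/mL, also a limit, so it has no exact position on the scale. Compound 3 (`CCC(Oc1ccc2c(c1)B(O)OC2)C(C)=O`) differs from compound 2 by one change, (hydrogen in place of ethyl on a saturated chain carbon bound to a carbonyl carbon), with hydrogen in place of ethyl on a saturated chain carbon bound to a carbonyl carbon. With only the limit of > 10 ug/mL in this assay, at which 2 of the 2 values shown sit, to go on, no step beyond the usual scatter is expected, in either direction. The expected change is a step that the limit leaves unreadable from compound 2 to compound 3. Compound 3 is expected at 15 ug/mL, with an estimated range of 8 ug/mL to 40 ug/mL.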

Compound 3, half-maximal inhibitory concentration: > 10 ug/mL
Compound 3 gave a limit, no number; the forecaster's own chance of this, stated with the estimate: 75%; the middle value does not contradict the limit.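

No step can be read between compound 2 and compound 3, since both results are limits and not numbers: the limit of > 10 ug/mL in this assay, at which 3 of the 3 values shown sit. The compounds shown leave open what number any of them would reach in this assay, and so whether hydrogen in place of ethyl changes anything.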